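Swapping a Nitrophenyl for a Dichlorophenyl Group

The source may report more compounds than this note shows. Statements on the series, on what has been measured and on what is new or still open speak of the compounds shown alone.

Compound 1, `COc1ccc2[nH]c3c(c2c1)CCNC31CCN(Cc2ccccc2)CC1`, in an assay on FRT cells for positive allosteric modulation of Cystic fibrosis transmembrane conductance regulator variant N1303K (Homo sapiens), in the presence of a further agent that is not named here; a higher number here means that more compound is needed for the effect, a lower number that less compound is needed: 12600 nM
Compound 2, `COc1ccc2[nH]c3c(c2c1)CCNC31CCN(Cc2ccc([N+](=O)[O-])cc2F)CC1`, in this assay: 5900 nM
Compound 3, `COc1ccc2[nH]c3c(c2c1)CCNC31CCN(Cc2cc(Cl)ccc2[N+](=O)[O-])CC1`, in this assay: 7100 nM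

Compound 3 gives the second highest of the three numbers in this assay. Its nearest neighbour is compound 2, as a 1.2-fold higher number from compound 2 to compound 3 (0.08 log units; within the scatter) shows, and the furthest is compound 1, with a 1.8-fold lower number from compound 1 to compound 3 (0.25 log units; within the scatter). The step from the unsubstituted phenyl to a substituted phenyl was a 2.1-fold lower number from compound 1 to compound 2 (0.33 log units; beyond the scatter) and a 1.8-fold lower number from compound 1 to compound 3 (0.25 log units; within the scatter), so both substituted phenyls sit close together.

Compound 4, `COc1ccc2[nH]c3c(c2c1)CCNC31CCN(Cc2ccc(Cl)cc2Cl)CC1`, differs from compound 3 in one place: 2,4-dichlorophenyl in place of 5-chloro-2-nitrophenyl on a saturated chain carbon bound to an amine nitrogen in a ring. Among the compounds with values here, no measured pair isolates the nitro-to-chlorine exchange, so the step must be read from the two substituted phenyls, which lie within the scatter of each other. A step within the scatter is therefore expected in this assay, namely a 1.1-fold lower number from compound 3 to compound 4 (0.04 log units; within the scatter). Compound 4 is estimated at 6500 nM, with a range from 3000 nM to 14000 nM.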

Compound 4, half-maximal effective concentration: 1800 nM
Compound 4: middle estimate off by 3.6-fold (0.56 log units), on the high side, outside the stated range (below it).
By their numbers in this assay, from the lowest: compound 4; then compounds 2, 3 and 1 (each within the scatter of the next, the first and the last beyond it).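

On the saturated chain carbon bound to an amine nitrogen in a ring, the choice of substituted phenyl now matters in this assay: the two nitro-bearing phenyls stayed within the scatter of each other, but 2,4-dichlorophenyl stands apart from both, with a 3.9-fold lower number from compound 3 to compound 4 (0.60 log units; beyond the scatter) and a 3.3-fold lower number from compound 2 to compound 4 (0.52 log units; beyond the scatter) as its steps. Within the data shown here, its step from the unsubstituted phenyl is also the largest seen at this position (with a 7.0-fold lower number from compound 1 to compound 4 (0.85 log units; beyond the scatter)), and compound 4 is the only compound here whose steps to all the others lie beyond the scatter. Nothing measured here accounts for this difference.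

The compounds shown leave open whether a single chlorine on the phenyl would give the same step or whether both chlorines are needed. Also open, from the compounds shown here alone, is how a bromine, a methyl or a trifluoromethyl group would compare with these chlorines.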